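Bromine Position and Growth Inhibition in Four Hydrazones

This account rests on a few compounds, and the source may have more. Where it says the series, first, only, none or still open, it means among the compounds named here.

Compound 2 `COc1cc(/C=N/Nc2nc(-c3cccc(Br)c3)cs2)cc(Br)c1OC` gives 66200 nM in a functional assay on HepG2 cells (Homo sapiens) for inhibition, read by MTT assay, with a stated time of 48 h; a lower number here means a stronger inhibitor, a higher number a weaker inhibitor. Compound 1 `COc1cc(/C=N/Nc2nc(-c3ccc(Br)cc3)cs2)cc(Br)c1OC` differs from it by 4-bromophenyl in place of 3-bromophenyl on an aromatic carbon, and in this assay compound 1 gives 64600 nM; that step is a 1.0-fold lower number from compound 2 to compound 1 (0.01 log units; within the scatter). Compound 3 `COc1cc(/C=N/Nc2nc(-c3cccc(Br)c3)cs2)c(Br)c(Br)c1OC` carries bromo in place of hydrogen on an aromatic carbon relative to compound 2. In this assay compound 3 reaches only a limit of the assay, > 100000 nM, which is the limit of > 100000 nM in this assay, at which 1 of the 3 values shown sits. The step is an at least 1.5-fold higher number from compound 2 to compound 3 (0.17 log units; that floor lies within the scatter). Compound 4 `COc1cc(/C=N/Nc2nc(-c3ccc(Br)cc3)cs2)c(Br)c(Br)c1OC` has not yet been measured in this assay; it differs from compound 3 by 4-bromophenyl in place of 3-bromophenyl on an aromatic carbon, the same change that leads from compound 2 to compound 1. Because a 1.0-fold lower number from compound 2 to compound 1 (0.01 log units; within the scatter) lay within the scatter, compound 4 is expected to stay close to the limit seen for compound 3, with an estimated 150000 nM in this assay, a step that the limit leaves unreadable from compound 3 to compound 4.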

Compound 4, half-maximal inhibitory concentration: > 100000 nM
Compound 4: a limit, no number (the forecaster's own chance of this, stated with the estimate: 70%); the middle value is on the limit's open side.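

Bromo in place of hydrogen on an aromatic carbon gives an at least 1.5-fold higher number from compound 1 to compound 4 (0.18 log units; that floor lies within the scatter). The step between compound 3 and compound 4 cannot be read, and in this assay each of these two compounds stands at a limit of the assay. What carries over from one core to the other is only that the change ends at a limit each time, and no size for the change is carried over: the same change on two cores in this assay, an at least 1.5-fold higher number (0.17 log units; that floor lies within the scatter) from compound 2 to compound 3 and an at least 1.5-fold higher number (0.18 log units; that floor lies within the scatter) from compound 1 to compound 4; the limit leaves it open whether they differ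

The compounds shown leave open how this assay would read with an amine or a carboxylic acid in place of the added bromo. They also leave open any order among the compounds at the limit: the limit of > 100000 nM in this assay, at which 2 of the 4 values shown sit.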